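The source may hold more compounds than are shown below. What is called first, only, known or untested is meant among the compounds shown, and "the series" means these compounds.

Going by the values given here, compound 1 `CCCCCCCCCCCCCCCC(=O)O[C@H]1[C@H](O)[C@H](n2ccc(N)nc2=O)O[C@@H]1CO` gives 0.24 ug/mL in a functional assay on HeLa cells (Homo sapiens) for cytotoxicity, read by cell counting, with a stated time of 48 h (a lower number here means that less compound is needed, a higher number that more compound is needed for the effect), the only full number in this set. Compound 2 `CCCCCCCCCCCCCCCCCCCCCC(=O)OC[C@H]1O[C@@H](n2ccc(N)nc2=O)[C@@H](O)[C@@H]1OC(=O)CCCCCCCCCCCCCCCCCCCCC` reaches only a limit in this assay, > 10 ug/mL. That is the limit of > 10 ug/mL in this assay, at which 1 of the 2 values shown sits. Compound 3 `CCCCCCCCCCC(=O)O[C@H]1[C@H](O)[C@H](n2ccc(N)nc2=O)O[C@@H]1CO` has not yet been measured in this assay; it differs from compound 1 by hydrogen in place of pentyl on a saturated chain carbon, ten or more bonds along the chain from a carbonyl carbon. Among the compounds with values here, no measured step of this kind is available, so for compound 3 the expected step is a 1.7-fold higher number from compound 1 to compound 3 (0.22 log units; within the scatter), no larger than the scatter, if anything toward more compound being needed. Compound 3 is therefore estimated at 0.4 ug/mL, between 0.1 ug/mL and 2 ug/mL.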

Compound 3, concentration for half-maximal effect: 0.04 ug/mL
Compound 3: middle estimate off by 10-fold (1.00 log units), on the high side; measured number below the stated range.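

Exchanging pentyl for hydrogen on a saturated chain carbon gives a 6.0-fold lower number from compound 1 to compound 3 (0.78 log units; beyond the scatter) in this assay. This far out on the chain, then, the change is not silent: removing pentyl leaves less compound needed for the effect. Compound 2 differs in more than one place and offers no comparison, and its value is a limit: the limit of > 10 ug/mL in this assay, at which 1 of the 3 values shown sits.

This single step shows no trend with chain length. Going by these compounds, whether a still shorter chain, or an amine at the chain end, would keep this direction remains open.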